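The compounds below may be only part of what the source reports. "The series", "measured", "known", "first", "only" and "open" are said of these compounds alone.

Compound 1 `O=S(=O)(NCCNCc1ccc(-c2ccccc2)cc1)c1cc(C(F)(F)F)cc(C(F)(F)F)c1`, compound 2 `O=S(=O)(NCCCNCC1COc2ccccc2O1)c1cc(C(F)(F)F)cc(C(F)(F)F)c1` and compound 3 `CC(C)(C)c1ccc(CNCCNS(=O)(=O)c2cc(C(F)(F)F)cc(C(F)(F)F)c2)cc1` share the same sulfonamide core and differ in the group carried beyond the amine. In a functional assay on ASPC1 cells (Homo sapiens) for inhibition, read by MTT assay, with a stated time of 72 h (a lower number here means a stronger inhibitor of growth, a higher number a weaker inhibitor of growth), compound 1 gives 2800 nM, compound 2 gives 2900 nM and compound 3 gives 14000 nM. Compound 2 therefore stands alongside compound 1, the two within the scatter of each other, while compound 3 sits clearly higher. Within the data shown here, the one step that can be read, a 5.0-fold higher number from compound 1 to compound 3 (0.70 log units; beyond the scatter), concerns a swap on an aromatic carbon and so lies at a different place from the change now in question. Compound 4 `COc1cccc(CNCCCNS(=O)(=O)c2cc(C(F)(F)F)cc(C(F)(F)F)c2)c1` differs from compound 2 by 3-methoxyphenyl in place of 2,3-dihydro-1,4-benzodioxin-2-yl on a saturated chain carbon bound to an amine nitrogen. Among the measured compounds shown here, no measured step touches that chain carbon, so direct guidance is lacking, and the only measured step of any kind was modest. The expected step is a 1.2-fold higher number from compound 2 to compound 4 (0.08 log units; within the scatter), that is, no change beyond the scatter, with a wide range to reflect the uncertainty. Compound 4 is expected to give 3500 nM, with a range from 1200 nM to 10000 nM.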

Compound 4, concentration for 50% growth inhibition: 3800 nM
The estimate for compound 4 lay 1.1-fold (0.04 log units) below the measured number, and the stated range covers the measured number.
By their numbers in this assay, from the lowest: compounds 1, 2 and 4 (each within the scatter of the next); then compound 3.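

In this assay, swapping (2,3-dihydro-1,4-benzodioxin-2-yl)methyl for 3-methoxybenzyl gives a 1.3-fold higher number from compound 2 to compound 4 (0.12 log units; within the scatter), so the two compounds cannot be told apart. Among these compounds, this is the first reading at this place, on a saturated chain carbon bound to an amine nitrogen, and it shows that the six-membered non-aromatic ring with its 2 hetero atoms can be replaced by a 3-methoxyphenyl group with no change beyond the scatter. Nothing shown accounts for this result.

As far as these compounds go, it remains open whether this tolerance extends to other groups at this place, such as an unsubstituted benzyl, or a benzyl carrying a carboxylic acid or an amine. From the compounds shown here alone, the effect of a longer chain alongside the 3-methoxybenzyl group also remains open.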